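This account rests on a few compounds, and the source may have more. Where it says the series, first, only, none or still open, it means among the compounds named here.

Measured so far:
compound 1 `Nc1nc(NCc2ccccc2)nc(-c2c(F)cccc2CO)n1` gives 3.69
compound 2 `Nc1nc(NCc2cccc(Cl)c2)nc(-c2ccccc2CO)n1` gives 4.97

In a functional assay on cells for positive allosteric modulation of G-protein coupled receptor 68 (Homo sapiens), read by a luciferase reporter and cAMP accumulation, with a stated time of 30 min, at pH 6.8 and pH 8.3, in the presence of a further agent that is not named here (on this read-out lower numbers stand for lower potency and higher numbers for higher potency (the scale is a negative logarithm)), compound 2 stands at the higher of the two values shown, with compound 1 as its nearest neighbour, and the gap between them is beyond the usual scatter. The two compounds differ in more than one place, so no single structural step can be read from their pair.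

Compound 3 `COc1ccc(CNc2nc(N)nc(-c3ccccc3CO)n2)cc1` is not yet measured. Compared with compound 2 it carries 4-methoxyphenyl in place of 3-chlorophenyl on a saturated chain carbon bound to a nitrogen on an aromatic ring. Among the compounds with values here, no measured pair isolates this exchange, and the two values in hand say nothing about it directly.

In this assay the expected step is a number 0.27 log units lower from compound 2 to compound 3 (within the scatter), at most a slight loss and possibly none beyond the scatter. For compound 3 the estimate in this assay is 4.7, with an expected range from 4 to 5.4.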

Compound 3, negative logarithm of the antagonist equilibrium constant: 3.34
For compound 3 the middle estimate is 1.36 log units above the measured one; the measured number lies below the stated range.
By their numbers in this assay, from the lowest: compound 3; then compound 1; then compound 2.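

In this assay, within the data shown here, the exchange of 3-chlorophenyl for 4-methoxyphenyl on a saturated chain carbon bound to a nitrogen on an aromatic ring gives a number 1.63 log units lower from compound 2 to compound 3 (beyond the scatter) and is the first single-place step, showing that potency at this position depends strongly on the group carried there while the rest of the structure stays fixed. Compound 1 differs from compound 2 and compound 3 in more than one place, so its steps to them cannot be read. No measurement in hand accounts for the size of this loss.

The exchange alters both the substituent and its place on the phenyl ring, and these two changes cannot be separated with the compounds shown. Going by these compounds, it also remains open how a carboxylic acid or an amine on that phenyl ring would compare with 3-chlorophenyl at this position.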